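Dibromo-hydroxyphenyl Replaces Methoxyphenyl on the Amide

The source may report more compounds than this note shows. Statements on the series, on what has been measured and on what is new or still open speak of the compounds shown alone.

Compound 3 `COc1ccccc1C(=O)Nc1ccc(Sc2nc3ccccc3s2)c(Cl)c1` carries a 2-methoxyphenyl on the carbonyl carbon of its amide. In an ADME assay on HEK293 cells (Homo sapiens) for cytotoxicity, read by reporter gene assay and resazurin assay, with a stated time of 48 h (on this read-out higher numbers stand for lower toxicity in this test and lower numbers for higher toxicity in this test), compound 3 gives > 100000 nM, which is a limit of the assay and not a number. Two relatives share the same core. Compound 1 `O=C(Nc1ccc(Sc2nc3ccccc3s2)c(Cl)c1)c1cccc(Br)c1` in this assay gives > 100000 nM, again a limit. Compound 2 `O=C(Nc1ccc(Sc2nc3ccccc3s2)c(Cl)c1)c1cccc(Br)c1O` in this assay gives 64000 nM. The ceiling the limit of > 100000 nM in this assay, at which 2 of the 3 values shown sit, means compound 3 stands at the top of what this test can report, and its true position may lie anywhere beyond that edge.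

Compound 4 `O=C(Nc1ccc(Sc2nc3ccccc3s2)c(Cl)c1)c1cc(Br)cc(Br)c1O` differs from compound 3 in one place (3,5-dibromo-2-hydroxyphenyl in place of 2-methoxyphenyl on a carbonyl carbon).

Two measured steps speak to this change. The step of an at least 1.5-fold higher number from compound 2 to compound 3 (0.19 log units; that floor lies within the scatter) runs largely in the opposite direction of the move to compound 4, and the step of an at least 1.5-fold lower number from compound 1 to compound 2 (0.19 log units; that floor lies within the scatter) shows what adding the hydroxy alone did. Both sit at a floor within the scatter, so neither reads as a clear shift. Among the compounds with values here, the second bromine has no measured counterpart here. Compound 4 is therefore expected to land near 50000 nM, between 15000 nM and 150000 nM, amounting to an estimated step of an at least 2.0-fold lower number from compound 3 to compound 4 (0.30 log units; that floor lies within the scatter).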

Compound 4, half-maximal cytotoxic concentration: 76000 nM
The estimate for compound 4 lay 1.5-fold (0.18 log units) below the measured number; the range from low to high includes it.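

Setting a second bromine on the aromatic ring gives a step with a real number at both ends (a 1.2-fold higher number from compound 2 to compound 4 (0.07 log units; within the scatter)), so in this assay the second bromine leaves no readable mark on this ring. The other two steps are floors only (an at least 1.3-fold lower number from compound 3 to compound 4 (0.11 log units; that floor lies within the scatter); an at least 1.3-fold lower number from compound 1 to compound 4 (0.11 log units; that floor lies within the scatter)), which means 3,5-dibromo-2-hydroxyphenyl on the carbonyl carbon cannot yet be told apart from either 2-methoxyphenyl or 3-bromophenyl. The true size of these two steps stays hidden because compound 1 and compound 3 are known only as limits: the limit of > 100000 nM in this assay, at which 2 of the 4 values shown sit.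

Across the compounds shown, this position on the amide takes quite different aromatic groups with no step that clears the usual scatter, so it remains open whether any change here can shift the cytotoxicity read-out clearly. A ring carrying an amine or a carboxylic acid in place of the hydroxy, or a longer chain on the carbonyl carbon in place of the ring, would test whether this tolerance holds beyond bromine, hydroxy and methoxy.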